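The source may hold more compounds than are shown below. What is called first, only, known or untested is meant among the compounds shown, and "the series" means these compounds.

- Compound 1 `CCN(c1ccc(C#N)c(Cl)c1)c1cc(-c2ccco2)ccc1C`: > 30000 nM
- Compound 2 `CCN(c1ccc(C#N)c(Cl)c1)c1cc(-c2ccnn2C)ccc1C`: 7290 nM
- Compound 3 `CCN(c1ccc(C#N)c(Cl)c1)c1cc(C2=CCCCC2)ccc1C`: "not determined" (no result reported)

The assay is a functional assay on PC-3 cells (Homo sapiens) for antiproliferative activity, read by CCK-8 assay, with a stated time of 6 days; on this read-out higher numbers stand for weaker inhibition and lower numbers for stronger inhibition. Compound 1 stands at > 30000 nM, which is a limit of the assay and not a number. Compound 3 has no number to start from: "not determined" (no result reported). Compound 4 `CCN(c1ccc(C#N)c(Cl)c1)c1cc(-c2cccnc2)ccc1C` differs from compound 3 as follows: pyridin-3-yl in place of cyclohex-1-en-1-yl on an aromatic carbon. Within the data shown here, the only measured step, an at least 4.1-fold lower number from compound 1 to compound 2 (0.61 log units; beyond the scatter), also exchanges the aromatic ring on this carbon, but it does not involve cyclohex-1-en-1-yl. No size or direction can therefore be expected for the step from compound 3. The closest guide is compound 2 at 7290 nM, which also carries a nitrogen-containing aromatic ring. Compound 4 is expected at about 10000 nM, with an estimated range of 3000 nM to 30000 nM.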

Compound 4, half-maximal inhibitory concentration: 11000 nM
Compound 4: the middle estimate sits 1.1-fold (0.04 log units) below what was measured; the measured number falls inside the stated range.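

In this assay, pyridin-3-yl in place of 1-methyl-1H-pyrazol-5-yl gives a 1.5-fold higher number from compound 2 to compound 4 (0.18 log units; within the scatter), so these two rings do not separate at this position. Pyridin-3-yl in place of furan-2-yl gives an at least 2.7-fold lower number from compound 1 to compound 4 (0.43 log units; beyond the scatter), so both nitrogen-containing rings now read lower than furan-2-yl. Compound 1 stands at a limit of the assay and not a number, which leaves the size of the steps from it open: the limit of > 30000 nM in this assay, at which 1 of the 4 values shown sits.

Steps from compound 3 cannot be read, so cyclohex-1-en-1-yl offers no comparison. As far as these compounds go, whether a pyridine ring carrying an amine or a carboxylic acid would move the number remains open.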